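Methoxy for Fluoro on a Shared Bis-Benzylidene Core

A few compounds are considered here, and "the series" means these few. Any claim that something is new, unique, unknown or untested is made for them only; others in the source may bear on it.

Three compounds built on the same core were tested in a functional assay on MOLT-4 cells (Homo sapiens) for cytotoxicity, with a stated time of 72 h; a lower number here means a stronger inhibitor, a higher number a weaker inhibitor. Compound 1 `Cc1ccc(/C=C2\CCC/C(=C\c3ccc([N+](=O)[O-])cc3)C2=O)cc1` gives 8440 nM, and compound 2 `COc1ccc(/C=C2\CCC/C(=C\c3ccccc3[N+](=O)[O-])C2=O)cc1` gives 8900 nM. Compound 3 `O=C1/C(=C/c2ccc(F)cc2)CCC/C1=C\c1cccc([N+](=O)[O-])c1` gives 5120 nM, the lowest of the three numbers, though its gaps to compound 1 and to compound 2 both lie within the usual scatter, so no order among the three can be read from these values.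

Compound 4 `COc1ccc(/C=C2\CCC/C(=C\c3cccc([N+](=O)[O-])c3)C2=O)cc1` has not yet been measured in this assay. It differs from compound 3 in one place: methoxy in place of fluoro on an aromatic carbon. The rest of the molecule is unchanged.

Going by the values given here, no measured pair in this set isolates this exchange, so there is no directly comparable step to lean on. The three measured values all sit close together, and compound 2, which also carries a methoxy group, gives 8900 nM, a number within the scatter of compound 3. On that basis compound 4 is expected to stay near compound 3, with the step from compound 3 to compound 4 estimated at a 1.3-fold higher number from compound 3 to compound 4 (0.10 log units; within the scatter), not clearly beyond the scatter in either direction. The estimated value for compound 4 in this assay is 6500 nM, with a range from 3000 nM to 14000 nM.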

Compound 4, half-maximal inhibitory concentration: 7980 nM
The estimate for compound 4 lay 1.2-fold (0.09 log units) below the measured number, within the range that was stated.
By their numbers in this assay, from the lowest: compounds 3, 4, 1 and 2 (each within the scatter of the next).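

Going by these compounds alone, compounds 3 and 4 form the first pair in the set that differs in one place only, and in this assay the exchange of 4-fluorophenyl for 4-methoxyphenyl gives a 1.6-fold higher number from compound 3 to compound 4 (0.19 log units; within the scatter). At this aromatic carbon, para to a large group, the change adds one heavy atom and one hydrogen-bond acceptor, yet it produces no difference that can be told from the scatter, so this position accepts either group with no readable change in this cytotoxicity read-out. Nothing among the data offers an explanation for this outcome.

The compounds shown leave open whether a group of another kind at this same place, such as an amine or a carboxylic acid, would move the number beyond the scatter. They also leave open whether the exchange of fluoro for methoxy would read the same with the nitro group placed as in compound 1 or compound 2, since this single step rests on one arrangement of the shared core.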